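Swapping the Ethylpyrimidine Arm for a Methoxypyridine

A few compounds are considered here, and "the series" means these few. Any claim that something is new, unique, unknown or untested is made for them only; others in the source may bear on it.

Compound 1 `COc1ncc(-c2nc(C(F)(F)F)sc2N2CCN(C(=O)Cn3nc(C)nc3C)[C@H](C)C2)cn1` and compound 2 `CCc1ncc(-c2nc(C(F)(F)F)sc2N2CCN(C(=O)Cn3nc(C)nc3C)[C@H](C)C2)cn1` share one core and differ in a single group on it. In a functional assay on CHO-K1 cells for antagonist activity at C-X-C chemokine receptor type 3 (Homo sapiens), read by FLIPR, with a stated time of 10 min (on this read-out lower numbers stand for stronger inhibition and higher numbers for weaker inhibition), compound 1 gives 25 nM, and compound 2 gives 14 nM. The step of a 1.8-fold lower number from compound 1 to compound 2 (0.25 log units; within the scatter) lies within the scatter, so compound 2 carries the lower of the two numbers without being separable from compound 1. Compound 3 `COc1ccc(-c2nc(C(F)(F)F)sc2N2CCN(C(=O)Cn3nc(C)nc3C)[C@H](C)C2)cn1` has not yet been measured. It differs from compound 2 by 6-methoxypyridin-3-yl in place of 2-ethylpyrimidin-5-yl on an aromatic carbon. Among the measured compounds shown here, the only measured step, from compound 1 to compound 2, exchanged methoxy for ethyl on the same ring and changed little; the alteration of the ring itself has no measured counterpart. The step from compound 2 to compound 3 in this assay is therefore expected to be a 1.8-fold higher number from compound 2 to compound 3 (0.25 log units; within the scatter), small and of uncertain direction. Compound 3 is estimated at 25 nM, with a range from 8 nM to 80 nM.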

Compound 3, half-maximal inhibitory concentration: 18 nM
Compound 3: the middle estimate sits 1.4-fold (0.14 log units) above what was measured; the measured number falls inside the stated range.
By their numbers in this assay, from the lowest: compounds 2, 3 and 1 (each within the scatter of the next).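

The measured change now reaches the ring itself: 6-methoxypyridin-3-yl, in place of 2-ethylpyrimidin-5-yl or of 2-methoxypyrimidin-5-yl, leaves the number in this assay within the scatter (a 1.3-fold higher number from compound 2 to compound 3 (0.11 log units; within the scatter); a 1.4-fold lower number from compound 1 to compound 3 (0.14 log units; within the scatter)). At this position on the five-membered aromatic ring with 1 nitrogen and 1 sulfur, an aromatic ring with 1 hetero atom therefore cannot be told apart from one with 2 hetero atoms, whether it carries methoxy or the pyrimidine carries ethyl. Nothing available bears on why these three numbers lie together.

As far as these compounds go, all three compounds keep a six-membered aromatic ring with a small group on it, so what a plain phenyl ring or a morpholine at this place would do remains open. Equally open, from the compounds shown here alone, is whether a carboxylic acid or a longer chain on the ring would leave the number as undisturbed.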